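Extending an Amide Side Chain in a Hormone Receptor Series

This account rests on a few compounds, and the source may have more. Where it says the series, first, only, none or still open, it means among the compounds named here.

Compound 1 `COc1ccc([N+](=O)[O-])cc1CSc1nc2cc(NC(=O)NC(C)(C)C)ccc2n1Cc1ccncc1` and compound 2 `CCCn1c(SCc2cc([N+](=O)[O-])ccc2OC)nc2cc(NC(=O)NC(C)(C)C)cc(C(=O)NC)c21` share a common core and were both tested in an assay on isolated protein for inhibition of Gonadotropin-releasing hormone receptor (Homo sapiens); on this read-out lower numbers stand for stronger inhibition and higher numbers for weaker inhibition. In this assay compound 1 gives 47 nM. Compound 2 gives 41 nM, and the gap between compound 2 and compound 1 lies within the scatter of repeated measurements, so the two stand together rather than apart. Compound 3 `CCCn1c(SCc2cc([N+](=O)[O-])ccc2OC)nc2cc(NC(=O)NC(C)(C)C)cc(C(=O)NCCCN(C)C)c21` has not yet been measured. It differs from compound 2 in a single place: 2-(dimethylamino)ethyl in place of hydrogen on a saturated chain carbon bound to an amide-type nitrogen. Within the data shown here, no measured pair differs in this way, so there is no earlier step to lean on. With nothing known about the effect of this change, the expectation is a step for compound 3 no larger than the scatter, with a slight lean toward a lower number, which amounts to an expected step of a 1.4-fold lower number from compound 2 to compound 3 (0.14 log units; within the scatter). For compound 3 in this assay the estimated value is 30 nM, with an expected range from 8 nM to 120 nM.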

Compound 3, half-maximal inhibitory concentration: 170 nM
Compound 3: middle estimate off by 5.7-fold (0.75 log units), on the low side, and the stated range ends below it.
By their numbers in this assay, from the lowest: compounds 2 and 1 (each within the scatter of the next); then compound 3.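

Extending the methylcarbamoyl group of compound 2 into the (3-(dimethylamino)propyl)carbamoyl group of compound 3 gives, in this assay, a 4.1-fold higher number from compound 2 to compound 3 (0.62 log units; beyond the scatter). Since a higher number stands for weaker inhibition, this position is not indifferent to what it carries, and this longer chain ending in an amine gives up a modest part of the inhibition seen with the small methyl group. Among these compounds, no earlier pair differed at this place. Among the compounds shown here, nothing measured so far bears on why the number rises, so the result records the size of the step and gives no explanation for it.

The compounds shown leave open whether the step follows from the added length or from the dimethylamino group at the chain's end, a question that a plain butyl chain with no amine on the same amide nitrogen could help to separate. They also leave open how a shorter chain carrying the same amine, or a chain of this length ending in a hydroxyl group or a carboxylic acid, would read on this assay.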